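From isopropyl to cyclopentylmethyl on a nitrogen

The source may hold more compounds than are shown below. What is called first, only, known or untested is meant among the compounds shown, and "the series" means these compounds.

Compound 1 `CC(C)Nc1ccc(NC(=O)c2cc(Cl)ccc2O)c(Cl)c1` gives 11000 nM
Compound 2 `CC(C)CNc1ccc(NC(=O)c2cc(Cl)ccc2O)c(Cl)c1` gives 60000 nM

Both values come from an ADME assay on A549 cells (Homo sapiens) for cytotoxicity, read by resazurin assay, with a stated time of 48 h; a lower number here means that less compound is tolerated, a higher number that more compound is tolerated. For the measured compounds named here, compound 1 holds the lower of the two numbers, and its only measured neighbour is compound 2. Compound 3 `O=C(Nc1ccc(NCC2CCCC2)cc1Cl)c1cc(Cl)ccc1O` has not yet been measured. It differs from compound 1 as follows: cyclopentylmethyl in place of isopropyl on a nitrogen on an aromatic ring. In short, cyclopentylmethyl stands in place of isopropyl on a nitrogen on an aromatic ring.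

Going by the values given here, only one measured step bears on this change. Isobutyl in place of isopropyl, also on a nitrogen on an aromatic ring, gave a 5.5-fold higher number from compound 1 to compound 2 (0.74 log units; beyond the scatter) and this step lies beyond the scatter. Among the compounds with values here, it is a single step, and no measured compound carries a ring in this place, so the data offer a direction but no firm size. A move to a higher number is therefore expected, probably of a similar or smaller size than that one step. The expected step is a 2.7-fold higher number from compound 1 to compound 3 (0.44 log units; beyond the scatter). Compound 3 is estimated at 30000 nM, with an expected range from 11000 nM to 85000 nM.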

Compound 3, half-maximal cytotoxic concentration: 21500 nM
Compound 3: middle estimate off by 1.4-fold (0.14 log units), on the high side; the range from low to high includes it.
By their numbers in this assay, from the lowest: compounds 1 and 3 (each within the scatter of the next); then compound 2.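

In this assay the ring-bearing cyclopentylmethyl group gives a 2.0-fold higher number from compound 1 to compound 3 (0.29 log units; within the scatter) and so cannot be told apart from isopropyl on this nitrogen, whereas isobutyl gave a 5.5-fold higher number from compound 1 to compound 2 (0.74 log units; beyond the scatter) at the same place. The direct comparison between the two larger groups gives a 2.8-fold lower number from compound 2 to compound 3 (0.45 log units; beyond the scatter) and shows that cyclopentyl in place of isopropyl on the saturated chain carbon bound to the nitrogen does make a difference, so the change seen with isobutyl does not carry over to every carbon-only group at this position, and among these three compounds only compound 2 stands apart. No measurement shown here accounts for this difference between the isobutyl and cyclopentylmethyl groups.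

The compounds shown leave open whether the gap to compound 2 belongs to the ring itself, a question that a straight butyl chain, a cyclobutylmethyl group or a cyclohexylmethyl group on the same nitrogen could help to settle. They also leave open how this position responds to a group carrying a hydroxyl or an amine, since all three groups shown contain carbon only.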